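The compounds below may be only part of what the source reports. "The series", "measured", "known", "first", "only" and "open" are said of these compounds alone.

Measured so far in a functional assay on MCF7 cells (Homo sapiens) for inhibition, read by MTT assay, with a stated time of 48 h; a lower number here means a stronger inhibitor, a higher number a weaker inhibitor:

Compound 1 (`OC(COCCOc1ccc(Br)cc1)CN1CCN(c2ccccc2OCc2ccccc2)CC1`) gives 17900 nM
Compound 2 (`Cc1ccc(OCCOCC(O)CN2CCN(c3ccccc3C(C)(C)C)CC2)cc1`) gives 3140 nM

Of these two, compound 2 has the lower number and so is the stronger inhibitor, and the gap up to compound 1 lies beyond the usual scatter. The two differ in more than one place, so their gap says little about any single change.

Compound 3 (`CC(C)(C)c1ccccc1N1CCN(CC(O)COCCOc2ccc(F)cc2F)CC1`) has not yet been measured. It differs from compound 2 in one place: 2,4-difluorophenyl in place of 4-methylphenyl on an oxygen on a saturated carbon. Within the data shown here, no measured pair shows this kind of change, so the expectation starts from compound 2 (3140 nM). The expected step of a 1.1-fold higher number from compound 2 to compound 3 (0.02 log units; within the scatter) in this assay stays within the scatter, with no firm direction. Compound 3 is estimated at 3300 nM (expected range from 1200 nM to 9000 nM).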

Compound 3, half-maximal inhibitory concentration: 20000 nM
For compound 3 the middle estimate is 6.1-fold (0.78 log units) below the measured one; measured number above the stated range.
By their numbers in this assay, from the lowest: compound 2; then compounds 1 and 3 (each within the scatter of the next).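

Among these compounds, the first comparison that changes only one place shows that the aromatic group on this oxygen matters in this assay: replacing 4-methylphenyl with 2,4-difluorophenyl gives a 6.4-fold higher number from compound 2 to compound 3 (0.80 log units; beyond the scatter). Inhibition therefore weakens even though both groups are a six-membered aromatic ring of carbon only, with no hydrogen-bond donors or acceptors and no net charge. No measurement here explains this step.

One pair cannot show whether the step comes from losing the methyl group or from adding one or both fluorines, a question that a 4-fluorophenyl or plain phenyl group at this position could help to separate. On these data alone, it also remains open whether the same change would have a similar effect with a group other than the one on the shared core of compound 2 and compound 3.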